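Thiophene for furan on the dihydropyrimidinone core

The source may report more compounds than this note shows. Statements on the series, on what has been measured and on what is new or still open speak of the compounds shown alone.

Measured so far:
compound 1, `CCN(CC)C(=O)C1=C(C)NC(=O)NC1c1ccsc1`: 35%
compound 2, `CCC(CC)OC(=O)C1=C(C)NC(=O)NC1c1ccco1`: 1%

Of the compounds shown here, two have been tested in an assay on membranes from HeLa cells for displacement of a labelled ligand from adenosine receptor A3 (Homo sapiens), read by scintillation counting, with a stated time of 180 min, tested at 1 uM; a lower number here means less inhibition, a higher number more inhibition at the concentration tested (going by the name of the read-out). Compound 1 gives 35% in this assay, and compound 2 gives 1%, the lowest of the two numbers. The gap between them lies beyond the usual scatter of the assay, so compound 2 stands clearly under compound 1 on what has been measured.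

Compound 3, `CCC(CC)OC(=O)C1=C(C)NC(=O)NC1c1ccsc1`, has not yet been measured in this assay. It is reached from compound 2 by one change: thiophen-3-yl in place of furan-2-yl on a saturated ring carbon

The pentan-3-yl ester of compound 2 is kept, and the thiophen-3-yl of compound 3 is the same aromatic ring that appears in compound 1, which gives 35% in this assay. Within the data shown here, because compound 2 gives 1%, there is little room below it, and the only other number known is higher. A rise of modest size is therefore expected in this assay, a number 11 percentage points higher from compound 2 to compound 3 (beyond the scatter), though a change no larger than the scatter would not be surprising. The estimate for compound 3 is 12%, expected to fall between 0% and 35%.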

Compound 3, a percentage reported as inhibition, at one concentration (the size of the read-out at that concentration, not a potency): 6%
Estimate against measurement, compound 3: 6 percentage points above; measured number inside the range.
By their numbers in this assay, from the lowest: compounds 2 and 3 (each within the scatter of the next); then compound 1.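

In this assay, thiophen-3-yl in place of furan-2-yl on a saturated ring carbon amounts to a number 5 percentage points higher from compound 2 to compound 3 (within the scatter), so with the pentan-3-yl ester held fixed, the two aromatic rings cannot be told apart at this position. Compound 3 also links the other two compounds through a change at a second place: (pentan-3-yl)oxy in place of diethylamino on a carbonyl carbon amounts to a number 29 percentage points lower from compound 1 to compound 3 (beyond the scatter), which shows that thiophen-3-yl alone does not carry the higher number of compound 1, and that with this ring held fixed the number follows the group on the carbonyl. Nothing available explains why either exchange has the size it has.

The compounds shown leave open whether diethylamino on the carbonyl carbon would give a similar number with furan-2-yl on the ring carbon, so it cannot yet be said whether the two places act independently. They also leave open how a phenyl ring on the saturated ring carbon, or a piperidine amide or an ethyl ester on the carbonyl carbon, would read in this assay.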